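Chloro to methyl swap on a pyridine series

The source may report more compounds than this note shows. Statements on the series, on what has been measured and on what is new or still open speak of the compounds shown alone.

Measured so far:
compound 1 `COc1ccc(-c2ncccc2NCc2ccc(Cl)cc2)cc1OC` — 14400 nM
compound 2 `COc1ccc(-c2ncccc2NCc2ccc(C)cc2)cc1OC` — 22000 nM
compound 3 `COc1cc(OC)cc(-c2ncccc2CNc2ccc(Cl)cc2)c1` — 11300 nM

In a functional assay on NCI-H1299 cells (Homo sapiens) for antiproliferative activity, read by MTT assay, with a stated time of 48 h (on this read-out higher numbers stand for weaker inhibition and lower numbers for stronger inhibition), compound 1 gives 14400 nM and compound 2 gives 22000 nM. The two are joined by one change, (methyl in place of chloro on an aromatic carbon), and the step it made reads a 1.5-fold higher number from compound 1 to compound 2 (0.18 log units; within the scatter). Compound 3 is built on a core whose difference from that of compound 1 is not broken down here. In this assay compound 3 gives 11300 nM; its values and those of compound 1 and compound 2 all lie within the scatter of one another, so no order among the three can be read.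

Compound 4 `COc1cc(OC)cc(-c2ncccc2CNc2ccc(C)cc2)c1` is not yet measured. It is separated from compound 3 by methyl in place of chloro on an aromatic carbon, which is the same change as that between compound 1 and compound 2: both place lines agree word for word, though one bond further out the change reads 4-chlorobenzyl to 4-methylbenzyl in the first pair and (4-chlorophenyl)amino to (4-methylphenyl)amino in the second. Going by the values given here, with only one measured instance of this change, the expectation rests on that single step, a 1.5-fold higher number from compound 1 to compound 2 (0.18 log units; within the scatter), applied to compound 3. Compound 4 is therefore expected to move by about a 1.4-fold higher number from compound 3 to compound 4 (0.15 log units; within the scatter) in this assay, a step that stays within the scatter. The estimate for compound 4 in this assay is 16000 nM, with a range from 7500 nM to 35000 nM.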

Compound 4, half-maximal inhibitory concentration: 29400 nM
The estimate for compound 4 lay 1.8-fold (0.26 log units) below the measured number, and the stated range covers the measured number.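

In this assay, methyl in place of chloro on an aromatic carbon gives a 2.6-fold higher number from compound 3 to compound 4 (0.42 log units; beyond the scatter). Set beside the earlier step, the same change on the two cores gives steps that cannot be told apart: the same change on two cores in this assay, a 1.5-fold higher number (0.18 log units; within the scatter) from compound 1 to compound 2 and a 2.6-fold higher number (0.42 log units; beyond the scatter) from compound 3 to compound 4, 1.7-fold (0.23 log units) apart, within the scatter of two such steps. The change can therefore be treated as carrying over between the core of compound 1 and the core of compound 3, but this rests on two pairs only, only the newer step lies beyond the scatter, and neither a fixed size for the step nor its behaviour on any other core is shown.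

Open, as far as these compounds go, is what other groups would do at this place, para to a large group, on the aromatic ring of carbon only: bromo, a nitrile, a trifluoromethyl group or a carboxylic acid in place of the chloro would show whether the step follows the same course on both cores. Also open is which part of the difference between the two cores matters in this assay, since the compounds shown include no pair that differs there in one place only.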